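Sulfanyl to dimethoxy-amine swap on the shared core

The source may report more compounds than this note shows. Statements on the series, on what has been measured and on what is new or still open speak of the compounds shown alone.

For the measured compounds named here, compound 1 `CCc1nc(-c2ccc(Cl)cc2Cl)c(CC)nc1SC(C)CC` gives the highest number of the three measured so far in an assay on IMR-32 cells for displacement of a labelled ligand from corticotropin-releasing factor receptor 1 (Homo sapiens), read by scintillation counting, with a stated time of 2 h (on this read-out lower numbers stand for stronger inhibition and higher numbers for weaker inhibition), at 401 nM. Compound 2 `CCc1nc(-c2cnc(OC)nc2OC)c(CC)nc1NC(CC)CC` gives 17.2 nM in this assay, and compound 3 `CCc1nc(NC(CC)CC)c(OC)nc1-c1ccc(OC)cc1C(F)(F)F` gives 2.2 nM; both carry an amino group where compound 1 carries the sulfanyl group. Compound 4 `CCc1nc(-c2ccc(Cl)cc2Cl)c(CC)nc1NC(COC)COC` is the next compound, differing from compound 1 in one place: (2-methoxy-1-(methoxymethyl)ethyl)amino in place of (sec-butyl)sulfanyl on an aromatic carbon. Going by the values given here, no single-change step between measured compounds is available, so the size of the step rests on the gap alone. A move toward the amine-bearing compounds is expected, beyond the scatter, so compound 4 is estimated at 40 nM (range 10 nM to 160 nM), the step of a 10-fold lower number from compound 1 to compound 4 (1.00 log units; beyond the scatter) being the expected change.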

Compound 4, inhibition constant: 224 nM
For compound 4 the middle estimate is 5.6-fold (0.75 log units) below the measured one; measured number outside the range, above it.
By their numbers in this assay, from the lowest: compound 3; then compound 2; then compounds 4 and 1 (each within the scatter of the next).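

At this position on the shared core, (2-methoxy-1-(methoxymethyl)ethyl)amino in place of (sec-butyl)sulfanyl gives a 1.8-fold lower number from compound 1 to compound 4 (0.25 log units; within the scatter) in this assay. Within this pair, a larger group with an amino link and more hydrogen-bond acceptors is therefore tolerated, and the swap does not separate the two compounds. No supporting evidence explains this result.

Open, from the compounds shown here alone, is what (sec-butyl)amino at this position would give on the core of compound 1, which would separate the linking atom from the chain. Going by these compounds, a longer alkyl chain on the same amino link also remains open.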